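Moving the Extra Carbon from Ring to Chain

The source may hold more compounds than are shown below. What is called first, only, known or untested is meant among the compounds shown, and "the series" means these compounds.

Of the compounds shown here, two with a shared core have been measured in a functional assay on HEK293 cells for antagonist activity at P2X purinoceptor 7 (Homo sapiens), read by fluorescence, with a stated time of 2 h; on this read-out lower numbers stand for stronger inhibition and higher numbers for weaker inhibition. Compound 1 `O=C(CCc1ccccc1)NNc1c(Cl)cncc1Cl` gives 650 nM in this assay. Going by the values given here, compound 2 `Cc1ccc(CCC(=O)NNc2c(Cl)cncc2Cl)cc1`, which carries a methyl in place of hydrogen on an aromatic carbon, gives 1400 nM in this assay; this is the higher of the two numbers recorded so far, and the single measured step, a 2.2-fold higher number from compound 1 to compound 2 (0.33 log units; beyond the scatter), is a modest rise that lies beyond the scatter.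

Compound 3 `O=C(CCCc1ccccc1)NNc1c(Cl)cncc1Cl` has not yet been measured. It differs from compound 2 in one place: benzyl in place of 4-methylphenyl on a saturated chain carbon, two bonds along the chain from a carbonyl carbon. The two compounds contain the same atoms joined differently, so the carbon that sat on the ring in compound 2 now lengthens the chain. Among the compounds with values here, the only measured step, a 2.2-fold higher number from compound 1 to compound 2 (0.33 log units; beyond the scatter), shows what adding the ring methyl did; read in reverse, removing it would point back toward the number of compound 1. Within the data shown here, no measured step shows what lengthening the chain does, so that part of the change is uncharted. Compound 3 is therefore expected to come in with a modestly lower number, a 1.8-fold lower number from compound 2 to compound 3 (0.24 log units; within the scatter), in this assay. The estimate for compound 3 is 800 nM, with a range from 300 nM to 2500 nM.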

Compound 3, half-maximal inhibitory concentration: 770 nM
Compound 3: the middle estimate sits 1.0-fold (0.02 log units) above what was measured; measured number inside the range.
By their numbers in this assay, from the lowest: compounds 1, 3 and 2 (each within the scatter of the next, the first and the last beyond it).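

In this assay, moving the carbon from the ring to the chain gives a 1.8-fold lower number from compound 2 to compound 3 (0.26 log units; within the scatter), a step that stays within the scatter, so the exchange of 4-methylphenyl for benzyl at this position cannot be told apart from no change. The first view of a longer chain alone, benzyl in place of phenyl, gives a 1.2-fold higher number from compound 1 to compound 3 (0.07 log units; within the scatter), also within the scatter, so compound 3 cannot be separated from either compound 1 or compound 2, even though those two lie beyond the scatter of each other. Nothing measured here offers an explanation for these numbers.

Still open, on these data alone, is whether a chain with yet another saturated carbon would stay within the scatter of compound 1, or whether the number would move clearly once the chain grew further. Also open, as far as these compounds go, is what a methyl on the ring of compound 3 would do when the longer chain and the ring methyl are combined, and how other groups, such as a methoxy or a chlorine on the ring or an amine on the chain, would read out.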